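Three limits, then a piperazine

The source may hold more compounds than are shown below. What is called first, only, known or untested is meant among the compounds shown, and "the series" means these compounds.

Compound 1 `Cc1ccccc1-c1cc(C(=O)N2CCC3(CC2)CC(=O)c2nn(C(C)(C)C)cc2O3)c2ccccc2n1`: > 10000 nM
Compound 2 `CC(C)(C)n1cc2c(n1)C(=O)CC1(CCN(C(=O)c3cc(-c4ccc(Cl)cc4)nc4ccccc34)CC1)O2`: > 10000 nM
Compound 3 `CN(C)c1ccc(-c2cc(C(=O)N3CCC4(CC3)CC(=O)c3nn(C(C)(C)C)cc3O4)c3ccccc3n2)cc1`: > 10000 nM

All three entries come from a functional assay on MDA-MB-231 cells (Homo sapiens) for inhibition, read by MTT assay, with a stated time of 72 h (on this read-out lower numbers stand for stronger inhibition and higher numbers for weaker inhibition), and each is a limit rather than a number. From the compounds shown here alone, compound 3 reaches only the limit of > 10000 nM, so its true position is unknown. Among the compounds with values here, the two other compounds offer no contrast, as the series so far shows (the limit of > 10000 nM in this assay, at which 3 of the 3 values shown sit).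

Compound 4 `CC(C)(C)n1cc2c(n1)C(=O)CC1(CCN(C(=O)c3cc(N4CCNCC4)nc4ccccc34)CC1)O2` keeps the shared core but carries piperazin-1-yl in place of 4-(dimethylamino)phenyl on an aromatic carbon next to the ring nitrogen: piperazin-1-yl in place of 4-(dimethylamino)phenyl on an aromatic carbon.

Three measured steps changed this same place: a step that the two limits leave unreadable from compound 1 to compound 2, a step that the two limits leave unreadable from compound 1 to compound 3 and a step that the two limits leave unreadable from compound 2 to compound 3. None has a readable size, and each only exchanges one substituted phenyl group for another. Within the data shown here, no measured compound carries a non-aromatic ring at this place, so the data give no firm direction for the new group. The most likely outcome in this assay is another limit, though a measurable value cannot be excluded. The expected change is a step that the limit leaves unreadable from compound 3 to compound 4, an estimate with wide uncertainty. For compound 4 the estimated value is 12000 nM, with an expected range of 3000 nM to 40000 nM.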

Compound 4, half-maximal inhibitory concentration: 4200 nM
Beside the measured number, compound 4's estimate is 2.9-fold (0.46 log units) above it, and the stated range covers the measured number.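

Within the data shown here, compound 4 is the first compound in this assay to give a measured number rather than a limit, which shows that the group on this aromatic carbon, next to the ring nitrogen, can change the read-out. Placing piperazin-1-yl here, a non-aromatic ring rather than a substituted phenyl group, gives an at least 2.3-fold lower number from compound 3 to compound 4 (0.37 log units; beyond the scatter), while the same group in place of 4-chlorophenyl gives an at least 2.3-fold lower number from compound 2 to compound 4 (0.37 log units; beyond the scatter) and in place of 2-methylphenyl gives an at least 2.3-fold lower number from compound 1 to compound 4 (0.37 log units; beyond the scatter). The steps among compound 1, compound 2 and compound 3 still cannot be read, and each of these compounds remains at a limit: the limit of > 10000 nM in this assay, at which 3 of the 4 values shown sit.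

Piperazin-1-yl is the only non-aromatic ring shown at this place, so it remains open whether the step depends on the ring as a whole or on its second nitrogen and that nitrogen's hydrogen. A morpholin-4-yl group, with oxygen in place of that nitrogen, or a 4-methylpiperazin-1-yl group, with a methyl group on it, would help separate these possibilities.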